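The source may report more compounds than this note shows. Statements on the series, on what has been measured and on what is new or still open speak of the compounds shown alone.

Measured in a functional assay on MDA-MB-435 cells (Homo sapiens) for cytotoxicity, read by MTT assay, with a stated time of 72 h; on this read-out higher numbers stand for weaker inhibition and lower numbers for stronger inhibition:
- compound 1 `Nc1ccc(Nc2c(C(=O)NCc3ccc(F)cc3)nc(Br)c3cccnc23)cc1`: 7000 nM
- compound 2 `N[C@H]1CC[C@H](Nc2c(C(=O)NCc3ccc(F)cc3)nc(Br)c3cccnc23)CC1`: 6000 nM
- compound 3 `C[C@H](Nc1c(C(=O)NCc2ccc(F)cc2)nc(Br)c2cccnc12)c1ccccc1`: > 20000 nM, a limit of the assay

Compound 3 has only a limit and no number. Compound 4 `NCCNc1c(C(=O)NCc2ccc(F)cc2)nc(Br)c2cccnc12` carries 2-aminoethyl in place of 1-phenylethyl on a nitrogen on an aromatic ring. Like 4-aminophenyl and 4-aminocyclohexyl, 2-aminoethyl holds an amino group. Exchanging those two gave a 1.2-fold lower number from compound 1 to compound 2 (0.07 log units; within the scatter). Moving to 1-phenylethyl gave an at least 2.8-fold higher number from compound 1 to compound 3 (0.45 log units; beyond the scatter) and an at least 3.3-fold higher number from compound 2 to compound 3 (0.52 log units; beyond the scatter). A modest move to a lower number in this assay is therefore expected, read as an at least 2.5-fold lower number from compound 3 to compound 4 (0.39 log units; beyond the scatter) in estimated terms. For compound 4 the estimate is 8000 nM, with an expected range of 3000 nM to 20000 nM.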

Compound 4, half-maximal inhibitory concentration: 12000 nM
Compound 4: middle estimate off by 1.5-fold (0.18 log units), on the low side; measured number inside the range.
By their numbers in this assay, from the lowest: compounds 2, 1 and 4 (each within the scatter of the next). At a limit, above all of these: compound 3.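

In this assay the open-chain 2-aminoethyl stands level with both ring-bearing amino groups, a 2.0-fold higher number from compound 2 to compound 4 (0.30 log units; within the scatter) and a 1.7-fold higher number from compound 1 to compound 4 (0.23 log units; within the scatter), so the ring of 4-aminophenyl and 4-aminocyclohexyl can go without a change beyond the scatter. Compound 3 has only a limit of the assay: the limit of > 20000 nM in this assay, at which 1 of the 4 values shown sits. The exchange of 1-phenylethyl for 2-aminoethyl therefore reads only as a floor, an at least 1.6-fold lower number from compound 3 to compound 4 (0.22 log units; that floor lies within the scatter), and does not yet separate these two groups.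

From the compounds shown here alone, whether the amino group itself counts stays open. 2-Hydroxyethyl or 3-aminopropyl on this nitrogen would bear on that question and on chain length.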